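The source may report more compounds than this note shows. Statements on the series, on what has been measured and on what is new or still open speak of the compounds shown alone.

Compound 1 `CC#CC(CC(=O)O)c1ccc(OCc2ccn3cc(-c4ccc(CC)cc4)nc3c2)cc1`: 671 nM
Compound 2 `CC#CC(CC(=O)O)c1ccc(OCc2ccc3nc(-c4ccc(F)cc4)cn3c2)cc1`: 623 nM

In an assay on isolated protein for agonist activity at Free fatty acid receptor 1 (Homo sapiens) (on this read-out lower numbers stand for an effect already at smaller amounts and higher numbers for an effect only at larger amounts of compound), compound 1 gives 671 nM. Of the two numbers shown, that of compound 1 is the larger, yet compound 2, with 623 nM in this assay, sits so close that the gap between the two is within the usual scatter; the two values show no real separation. Within the data shown here, no step between measured compounds that differ in one place is available, so nothing measured tells how a single change on the shared core shifts this assay.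

Compound 3 `CC#CC(CC(=O)O)c1ccc(OCc2ccn3cc(-c4ccc(F)cc4)nc3c2)cc1` has not been measured. It differs from compound 1 by fluoro in place of ethyl on an aromatic carbon. Compound 2 already carries a 4-fluorophenyl group on a related core and gives a number close to compound 1, so the change from ethyl to fluoro is expected to move this assay by little, with no direction beyond the scatter.

The step from compound 1 to compound 3 is therefore estimated as a 1.1-fold lower number from compound 1 to compound 3 (0.03 log units; within the scatter). For compound 3 in this assay the expected value is 620 nM, within a range from 250 nM to 1500 nM.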

Compound 3, half-maximal effective concentration: 783 nM
Compound 3: the middle estimate sits 1.3-fold (0.10 log units) below what was measured; the measured number falls inside the stated range.
By their numbers in this assay, from the lowest: compounds 2, 1 and 3 (each within the scatter of the next).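

In this assay, among these compounds, exchanging the 4-ethylphenyl group for a 4-fluorophenyl group on the shared core gives a 1.2-fold higher number from compound 1 to compound 3 (0.07 log units; within the scatter) and is the first single change that can be read directly. The position, an aromatic carbon of a six-membered aromatic ring of carbon only, para to a large group, therefore takes either ethyl or fluoro without any real separation on this read-out, so these two groups are not told apart here. Nothing at hand gives a reason why ethyl and fluoro read alike.

On these data alone, whether any group at this position can move the number beyond the scatter remains open; a methoxy group, a trifluoromethyl group, an amine, a carboxylic acid or a longer chain such as butyl in the place of ethyl would each bear on that. Also open, as far as these compounds go, is whether a 4-ethylphenyl group on the core of compound 2 would read the same as the 4-fluorophenyl group that compound carries.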